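Heteroaryl exchange on the shared core: cytotoxicity notes

This account rests on a few compounds, and the source may have more. Where it says the series, first, only, none or still open, it means among the compounds named here.

Measured in a functional assay on HeLa S3 cells (Homo sapiens) for cytotoxicity, read by XTT assay, with a stated time of 3 days; on this read-out lower numbers stand for stronger inhibition and higher numbers for weaker inhibition:
- Compound 1 `OC[C@H]1O[C@@H](n2cc(F)c3c(-c4ccco4)ncnc32)[C@H](O)[C@@H]1O`: 8000 nM
- Compound 2 `OC[C@H]1O[C@@H](n2cc(F)c3c(-c4nccs4)ncnc32)[C@H](O)[C@@H]1O`: 3100 nM

Compound 2 holds the lower of the two numbers, 3100 nM. Next is compound 3 `OC[C@H]1O[C@@H](n2cc(F)c3c(-c4c[nH]cn4)ncnc32)[C@H](O)[C@@H]1O`, with 1H-imidazol-4-yl in place of 1,3-thiazol-2-yl on an aromatic carbon. Within the data shown here, the only measured exchange at this place is a 2.6-fold lower number from compound 1 to compound 2 (0.41 log units; beyond the scatter), a modest step. With that single step as a guide, a similarly modest or smaller change is expected in this assay, leaning slightly towards a higher number. The expected step is a 1.3-fold higher number from compound 2 to compound 3 (0.11 log units; within the scatter). Compound 3 is estimated at 4000 nM, with an expected range of 1200 nM to 13000 nM.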

Compound 3, half-maximal inhibitory concentration: 12200 nM
Estimate against measurement, compound 3: 3.1-fold (0.48 log units) below; measured number inside the range.
By their numbers in this assay, from the lowest: compound 2; then compounds 1 and 3 (each within the scatter of the next).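

In this assay, the exchange at this place now covers three five-membered aromatic rings, and 1,3-thiazol-2-yl alone stands apart: 1H-imidazol-4-yl in its place gives a 3.9-fold higher number from compound 2 to compound 3 (0.59 log units; beyond the scatter). Against furan-2-yl, the same group gives a 1.5-fold higher number from compound 1 to compound 3 (0.18 log units; within the scatter), so these two cannot be ordered. Nothing available accounts for the gap between the two rings with 2 hetero atoms.

Open, as far as these compounds go, is whether an amine, a short alkyl chain or a pyridinyl ring at this place would match or pass compound 2. Also open, from the compounds shown here alone, is whether this order holds in other cells.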